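Propylsulfanyl added to the core of compound 3

The source may hold more compounds than are shown below. What is called first, only, known or untested is meant among the compounds shown, and "the series" means these compounds.

Compound 3 `O=C(COC(=O)C1=C2C(=NC1=O)c1cccc3cccc2c13)OCC(F)(F)C(F)(F)F` gives 48300 nM in an ADME assay on WI-38 cells (Homo sapiens) for antiproliferative activity, read by sulforhodamine B assay, with a stated time of 72 h (on this read-out lower numbers stand for stronger inhibition and higher numbers for weaker inhibition), and lies within the scatter of both other measured compounds. Compound 1 `C=CCOC(=O)C1=C2C(=NC1=O)c1cccc3c(SCCC)ccc2c13` gives 33200 nM and compound 2 `CCCSC(=O)COC(=O)C1=C2C(=NC1=O)c1cccc3cccc2c13` gives 25200 nM in this assay and neither separates from compound 3.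

Compound 4 `CCCSc1ccc2c3c(cccc13)C1=NC(=O)C(C(=O)OCC(=O)OCC(F)(F)C(F)(F)F)=C12` carries propylsulfanyl in place of hydrogen on an aromatic carbon of the shared core, and the ester side chain of compound 3 stays unchanged. Among the compounds with values here, the counted difference is propylsulfanyl in place of hydrogen on an aromatic carbon and no measured pair isolates this replacement.

Within the data shown here, the one measured step is a 1.9-fold higher number from compound 2 to compound 3 (0.28 log units; within the scatter) and it stays within the scatter, but it lies in the ester side chain and not at this place. Compound 1 carries propylsulfanyl on the core with a different ester, and its 33200 nM does not separate it from the compounds without that group.

No step beyond the scatter is therefore expected in this assay. The expected 1.4-fold lower number from compound 3 to compound 4 (0.14 log units; within the scatter) is small and without a firm direction. Compound 4 is estimated at 35000 nM with an expected range from 15000 nM to 80000 nM in this assay as a wide allowance for the missing direct comparison.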

Compound 4, half-maximal inhibitory concentration: 58800 nM
Beside the measured number, compound 4's estimate is 1.7-fold (0.23 log units) below it, within the range that was stated.
By their numbers in this assay, from the lowest: compounds 2, 1, 3 and 4 (each within the scatter of the next, the first and the last beyond it).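

In this assay, propylsulfanyl in place of hydrogen on an aromatic carbon of the shared core is now isolated by a direct pair, which gives a 1.2-fold higher number from compound 3 to compound 4 (0.09 log units; within the scatter) and so shows no separable effect of this change with the ester side chain of compound 3. With propylsulfanyl held on the core, (2,2,3,3,3-pentafluoropropoxy)carbonyl in place of vinyl on the ester chain gives a 1.8-fold higher number from compound 1 to compound 4 (0.25 log units; within the scatter), so this side-chain change does not separate either. No supporting data bear on why these numbers stay so close.

As far as these compounds go, whether an amine or a carboxylic acid on the same aromatic carbon, or a longer chain on the sulfur, would give a step beyond the scatter remains open. Also open, from the compounds shown here alone, is whether core propylsulfanyl would give the same result with the ester side chain of compound 2.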